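Methoxy-to-cyano swap carried from one core to another

A few compounds are considered here, and "the series" means these few. Any claim that something is new, unique, unknown or untested is made for them only; others in the source may bear on it.

Measured compounds:
compound 1, `CNCCN(C)c1nnnn1Cc1ccc(C#N)cc1`, 6%
compound 2, `CNCCN(C)c1nnnn1Cc1ccc(OC)cc1`, 0%
compound 3, `CNCCN(C)Cc1ccc(-c2ccc(OC)cc2)o1`, 38%

In an assay on cells for inhibition of protein arginine N-methyltransferase 1 (Homo sapiens), read by scintillation counting, with stated times of 15 min and 60 min, tested at 9 uM (on this read-out lower numbers stand for less inhibition and higher numbers for more inhibition at the one concentration tested (going by the name of the read-out)), compound 2 gives 0% and compound 1 gives 6%. The change between them is cyano in place of methoxy on an aromatic carbon, and the step it made is a number 6 percentage points higher from compound 2 to compound 1 (within the scatter), which is within the scatter and so shows no real movement on this read-out.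

Compound 3 gives 38% in this assay, the highest of the three numbers, beyond the scatter from both compound 1 and compound 2. How the core of compound 3 differs from the core of compound 2 is not broken down here.

Compound 4, `CNCCN(C)Cc1ccc(-c2ccc(C#N)cc2)o1`, is compound 3 with the same change applied: cyano in place of methoxy on an aromatic carbon. The place is described in the same words as for the step from compound 2 to compound 1, so the change is the same, made on the higher-reading core.

The expectation for compound 4 in this assay rests on compound 3 at 38% and on the flat earlier step a number 6 percentage points higher from compound 2 to compound 1 (within the scatter). The expected step is estimated as a number 2 percentage points higher from compound 3 to compound 4 (within the scatter), inside the scatter. Compound 4 is thus expected to give about 40%, with a likely range from 25% to 55%.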

Compound 4, a percentage reported as inhibition, at one concentration (the size of the read-out at that concentration, not a potency): 35%
Compound 4: middle estimate off by 5 percentage points, on the high side; the measured number falls inside the stated range.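

In this assay, cyano in place of methoxy on the core of compound 3 gives a number 3 percentage points lower from compound 3 to compound 4 (within the scatter), so the change leaves no real movement on this core either. Set side by side, the change reads the same on both cores: the same change on two cores in this assay, a number 6 percentage points higher (within the scatter) from compound 2 to compound 1 and a number 3 percentage points lower (within the scatter) from compound 3 to compound 4, 9 percentage points apart, within the scatter of two such steps This supports carrying the swap between these two cores without expecting a shift in this read-out, but it rests on one pair per core at a single concentration, gives no potency, and does not extend to other cores; the pair on the core of compound 2 also reads near the bottom of the scale, where a fall would barely register.

Still open, going by these compounds, is whether a group other than these two, such as an amine, a carboxylic acid or trifluoromethyl, would move the reading from the same place on the six-membered aromatic ring of carbon only. Also open, on these data alone, is how a longer chain in place of the side chain shared by all four compounds would read in this assay.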